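The compounds below may be only part of what the source reports. "The series", "measured", "known", "first", "only" and "open" are said of these compounds alone.

- compound 1 `Clc1ccc(Nc2nc(Nc3cn[nH]c3)ncc2Cl)cc1` gives 2570 nM
- compound 2 `Clc1ccccc1Nc1nc(Nc2cn[nH]c2)ncc1Cl` gives 1130 nM

In a functional assay on PC-3 cells (Homo sapiens) for antiproliferative activity, read by MTT assay, with a stated time of 48 h (on this read-out higher numbers stand for weaker inhibition and lower numbers for stronger inhibition), compound 1 stands at 2570 nM, the higher of the two numbers. Compound 3 `Fc1cnc(Nc2cn[nH]c2)nc1Nc1ccc(Cl)cc1` changes it once: fluoro in place of chloro on an aromatic carbon. Among the measured compounds shown here, the only measured step, a 2.3-fold lower number from compound 1 to compound 2 (0.36 log units; beyond the scatter), is modest and concerns the chlorophenyl group on nitrogen, not this carbon, so it gives only a rough idea of scale. No step beyond the scatter is therefore expected in this assay, and no direction can be favoured. Compound 3 is estimated at 2500 nM, within a range of 900 nM to 7000 nM. This estimate means an expected 1.0-fold lower number from compound 1 to compound 3 (0.01 log units; within the scatter).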

Compound 3, half-maximal inhibitory concentration: 10400 nM
Compound 3: the middle estimate sits 4.2-fold (0.62 log units) below what was measured, and the stated range ends below it.
By their numbers in this assay, from the lowest: compound 2; then compound 1; then compound 3.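

In this assay, the carbon para to the (1H-pyrazol-4-yl)amino group proves sensitive to its substituent: fluoro in place of chloro gives a 4.0-fold higher number from compound 1 to compound 3 (0.61 log units; beyond the scatter). Among the compounds shown here, the earlier compounds varied only the chlorophenyl group on nitrogen, so this is the first evidence that this carbon also affects the read-out, with chloro the better of the two groups tried here. No available evidence bears on the reason for this step. Going by these compounds, whether bromo, methyl or a nitrile on this carbon would match chloro remains open, as does the effect of the same fluoro change in compound 2.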